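This account rests on a few compounds, and the source may have more. Where it says the series, first, only, none or still open, it means among the compounds named here.

Of the compounds shown here, three have been measured in an assay on Prostate gland for inhibition of steroid 5-alpha-reductase (Rattus norvegicus); on this read-out higher numbers stand for weaker inhibition and lower numbers for stronger inhibition. Compound 1, `C/C(=C\C(=O)Nc1ccccc1OCCCC(=O)O)c1ccc2c(ccn2Cc2ccc(C)cc2)c1`, gives 88 nM. Compound 2, `C/C(=C\C(=O)Nc1ccccc1OCCCC(=O)O)c1ccc2c(ccn2Cc2ccc(F)cc2)c1`, gives 97 nM. These two share one core and differ in a single spot: methyl in place of fluoro on an aromatic carbon. That change produced a 1.1-fold lower number from compound 2 to compound 1 (0.04 log units; within the scatter), so the two numbers cannot be told apart.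

Compound 3, `C/C(=C\C(=O)Nc1ccc(F)cc1OCCCC(=O)O)c1ccc2c(ccn2C(c2ccccc2)c2ccccc2)c1`, gives 3.6 nM, the lowest of the three numbers and clearly set apart from compounds 1 and 2. Its core is not the same as that of compound 2, and the difference between the two cores is not broken down here.

Compound 4, `C/C(=C\C(=O)Nc1ccc(C)cc1OCCCC(=O)O)c1ccc2c(ccn2C(c2ccccc2)c2ccccc2)c1`, has not yet been measured. It differs from compound 3 in one place: methyl in place of fluoro on an aromatic carbon. Within the data shown here, this is the same kind of change as the one from compound 2 to compound 1, but not the same: in compound 1 the methyl sits on an aromatic carbon para to a large group, whereas in compound 4 it sits meta to a 3-carboxypropoxy group and para to a large group, on a different ring of the molecule.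

Because the earlier change gave a 1.1-fold lower number from compound 2 to compound 1 (0.04 log units; within the scatter), the expectation for compound 4 is a step of similar, small size, a 1.0-fold lower number from compound 3 to compound 4 (0.01 log units; within the scatter). Among the measured compounds shown here, compound 4 is therefore estimated at 3.5 nM, with a likely range from 1.5 nM to 9 nM; since only one earlier example of this change exists, and at another place, that range is kept wide.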

Compound 4, half-maximal inhibitory concentration: 14 nM
Compound 4: the middle estimate sits 4.0-fold (0.60 log units) below what was measured; the whole stated range lies below it.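

On the core of compound 3, methyl in place of fluoro gave a 3.9-fold higher number from compound 3 to compound 4 (0.59 log units; beyond the scatter), which in this assay means weaker inhibition. Set beside the earlier step, this shows that the same swap does not carry a fixed effect from one core to another in this series: the same change on two cores in this assay, a 1.1-fold lower number (0.04 log units; within the scatter) from compound 2 to compound 1 and a 3.9-fold higher number (0.59 log units; beyond the scatter) from compound 3 to compound 4, 4.3-fold (0.63 log units) apart, beyond the scatter of two such steps The two pairs differ both in the rest of the core and in where the swap sits, since in compound 4 the methyl is meta to a 3-carboxypropoxy group and para to a large group, so these two steps cannot show which of those differences matters, or predict the step on any further core.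

From the compounds shown here alone, it remains open whether a chloro or a methoxy group on that same aromatic carbon would give a number closer to that of compound 3 or to that of compound 4. Also open, going by these compounds, is how the swap from fluoro to methyl would behave at that same place on the core of compound 1, a comparison that could separate the place of the swap from the rest of the core.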